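Thiazolidinedione series: bromo for nitro at compound 3

The compounds below may be only part of what the source reports. "The series", "measured", "known", "first", "only" and "open" are said of these compounds alone.

Measured so far:
compound 1, `O=C1NC(=O)/C(=C/c2ccc(OCc3csc(-c4ccccc4)n3)cc2)S1`, 29.7%
compound 2, `O=C1NC(=O)/C(=C/c2ccc(OCCSc3nnc(-c4ccc([N+](=O)[O-])cc4)[nH]3)cc2)S1`, 18%

In a functional assay on the whole organism (plasma, strain Wistar) with Rattus norvegicus as the target, with a stated time of 15 days, at a dose of 100 mg/kg by the oral route (on this read-out higher numbers stand for a stronger effect at the one dose given and lower numbers for a weaker effect), compound 1 gives 29.7% and compound 2 gives 18%. Compound 2 stands lowest of the two numbers, its gap to compound 1 beyond the scatter. Compound 3 `O=C1NC(=O)/C(=C/c2ccc(OCCSc3nnc(-c4ccc(Br)cc4)[nH]3)cc2)S1` differs from compound 2 in one place: bromo in place of nitro on an aromatic carbon. For the measured compounds named here, no measured pair shows this change, so its size is unknown from the data; a step within the scatter, in either direction, is expected. Compound 3 is therefore estimated at 20% with a range of 8% to 35%. This estimate means an expected step of a number 2 percentage points higher from compound 2 to compound 3 (within the scatter).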

Compound 3, a percentage reported as activity, at one dose (the size of the read-out at that dose, not a potency): 28.5%
The estimate for compound 3 lay 8.5 percentage points below the measured number; low and high end bracket the measured number.
By their numbers in this assay, from the lowest: compound 2; then compounds 3 and 1 (each within the scatter of the next).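

In this assay, for the compounds shown here, the change from 4-nitrophenyl to 4-bromophenyl gives a number 10.5 percentage points higher from compound 2 to compound 3 (beyond the scatter) as the first one-place step, so the read-out responds to the group at this position on the aromatic ring. The step is modest and rests on this single pair. Nothing measured here accounts for it. On these data alone, whether chloro, an amine or a carboxylic acid at this position would move the read-out further remains open. As far as these compounds go, it is also open whether the same exchange gives a similar step on the core of compound 1.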